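Swapping Methyl for Chloro on a Growth-Inhibition Core

The source may report more compounds than this note shows. Statements on the series, on what has been measured and on what is new or still open speak of the compounds shown alone.

Compound 2 `Cc1ccc2c(c1)/C(=C\C(=O)OC(C)(C)C)C(=O)N2` and compound 1 `CCOC(=O)/C=C1/C(=O)Nc2ccccc21` share a core and were both tested in a functional assay on SK-BR-3 cells (Homo sapiens) for inhibition, read by CCK-8 assay, with a stated time of 72 h, tested at 20 uM; a higher number here means more inhibition of growth at the concentration tested, a lower number less inhibition of growth. In this assay compound 2 gives 88%, and compound 1 gives 85.5%, a gap within the usual scatter, so the two numbers cannot be told apart. Compound 3 `CC(C)(C)OC(=O)/C=C1/C(=O)Nc2ccc(Cl)cc21` has not been measured. It differs from compound 2 by chloro in place of methyl on an aromatic carbon. No such step has been measured among these compounds, so any shift is expected to stay within the scatter. Compound 3 is therefore estimated at 85%, between 70% and 95%. This means an expected step of a number 3 percentage points lower from compound 2 to compound 3 (within the scatter).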

Compound 3, percent growth inhibition at one concentration: 87.6%
Estimate against measurement, compound 3: 2.6 percentage points below, and the stated range covers the measured number.
By their numbers in this assay, from the lowest: compounds 1, 3 and 2 (each within the scatter of the next).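

Within the data shown here, this is the first measured change at this position: in this assay, chloro in place of methyl on an aromatic carbon gives a number 0.4 percentage points lower from compound 2 to compound 3 (within the scatter). At the single concentration tested, the read-out therefore does not separate these two groups. No measurement at hand bears on why they read alike.

Still open, on these data alone, is whether a different kind of group at this position, such as an amine or a carboxylic acid, would also leave the read-out in the same range. A longer chain there remains equally untested among the compounds shown.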